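A few compounds are considered here, and "the series" means these few. Any claim that something is new, unique, unknown or untested is made for them only; others in the source may bear on it.

Measured so far in an ADME assay on HOS cells (Homo sapiens) for cytotoxicity, read by a luciferase reporter and ATP content, with a stated time of 48 h; on this read-out higher numbers stand for lower toxicity in this test and lower numbers for higher toxicity in this test:
- compound 1 `O=C(NCc1ccc(F)c(Cl)c1)c1cc2cccnc2n(O)c1=O`: > 250000 nM (a limit)
- compound 2 `O=C(NCc1ccc(F)c(F)c1)c1cc2cccnc2n(O)c1=O`: > 250000 nM (a limit)
- compound 3 `O=C(NCc1ccc(F)c(Cl)c1)c1c(O)c2cccnc2n(O)c1=O`: 102000 nM

Within the data shown here, compound 3 gives 102000 nM, the only actual number so far. The other two results are limits, and they are recorded as the limit of > 250000 nM in this assay, at which 2 of the 3 values shown sit. Compound 3 therefore has no numerical neighbour to be ranked against.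

The next compound is compound 4 `O=C(NCc1ccc(F)cc1F)c1c(O)c2cccnc2n(O)c1=O`, which keeps the core of compound 3, including its hydroxy group. The change is 2,4-difluorophenyl in place of 3-chloro-4-fluorophenyl on a saturated chain carbon bound to an amide-type nitrogen.

Two measured steps can be consulted. The closer one, on the same aromatic group, is a step that the two limits leave unreadable from compound 1 to compound 2, so it offers no size to carry over. The other, an at least 2.4-fold lower number from compound 1 to compound 3 (0.38 log units; beyond the scatter), concerns a different part of the molecule, and compound 3 and compound 4 share that change.

With no readable step at this place, no shift beyond the scatter is expected in this assay, and no direction can be assigned. The expected result is a 1.0-fold lower number from compound 3 to compound 4 (0.01 log units; within the scatter). For compound 4 the estimate is 100000 nM, with an expected range of 40000 nM to 250000 nM.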

Compound 4, half-maximal cytotoxic concentration: 137000 nM
For compound 4 the middle estimate is 1.4-fold (0.14 log units) below the measured one, and the stated range covers the measured number.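

In this assay, among these compounds, a 1.3-fold higher number from compound 3 to compound 4 (0.13 log units; within the scatter) is the first readable step for a change of aromatic group on the saturated chain carbon bound to an amide-type nitrogen. With the hydroxy group of compound 3 retained, replacing 3-chloro-4-fluorophenyl with 2,4-difluorophenyl therefore gives no shift beyond the scatter. The earlier change of aromatic group, from compound 1 to compound 2, cannot be read because both compounds give a limit rather than a number: the limit of > 250000 nM in this assay, at which 2 of the 4 values shown sit.

Going by these compounds, it remains open whether 2,4-difluorophenyl would give the same outcome on the core of compound 1, which has no hydroxy group, and whether any step at this place would be readable on that core. Also open, on these data alone, is whether an aromatic ring bearing an amine or a carboxylic acid, or a longer chain in place of the saturated chain carbon, would move the number beyond the scatter on the core shared by compound 3 and compound 4.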